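The source may hold more compounds than are shown below. What is called first, only, known or untested is meant among the compounds shown, and "the series" means these compounds.

Compound 1 `CC1(C)CC(N)=Nc2ccc(Cl)cc21`: 80.5%
Compound 2 `CNC1=Nc2ccc(Cl)cc2C(C)(C)C1`: 91.9%

For the measured compounds named here, in a functional assay on MDA-MB-231 cells (Homo sapiens) for cytotoxicity, read by MTT assay, with a stated time of 72 h, tested at 1 uM, in the absence of a further agent (a higher number here means a weaker effect of the compound at the concentration tested, a lower number a stronger effect), compound 2 stands highest of the two numbers so far; its nearest neighbour is compound 1, and the step of a number 11.4 percentage points higher from compound 1 to compound 2 (beyond the scatter) lies beyond the scatter. Compound 3 `CCNC1=Nc2ccc(Cl)cc2C(C)(C)C1` differs from compound 2 by methyl in place of hydrogen on a saturated chain carbon bound to an amine nitrogen. Going by the values given here, the only measured step that bears on this is a number 11.4 percentage points higher from compound 1 to compound 2 (beyond the scatter), a modest rise; the present change is of the same kind, methyl to ethyl, one bond further out, and with compound 2 already high no step beyond the scatter is expected in this assay. For compound 3 the expected value is 93%, range 80% to 104%, an estimated step of a number 1.1 percentage points higher from compound 2 to compound 3 (within the scatter).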

Compound 3, a percentage reported as activity, at one concentration (the size of the read-out at that concentration, not a potency): 89.7%
The estimate for compound 3 lay 3.3 percentage points above the measured number; the range from low to high includes it.
By their numbers in this assay, from the lowest: compounds 1, 3 and 2 (each within the scatter of the next, the first and the last beyond it).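

In this assay the change from methylamino to ethylamino reads as a number 2.2 percentage points lower from compound 2 to compound 3 (within the scatter) and so adds no readable effect at this position. Ethyl in place of hydrogen on the amine nitrogen gives a number 9.2 percentage points higher from compound 1 to compound 3 (within the scatter) while methyl there gave a number 11.4 percentage points higher from compound 1 to compound 2 (beyond the scatter) and so the separation from compound 1 seen with methyl does not hold for ethyl. Nothing available explains either result. From the compounds shown here alone, whether a longer chain, a branched isopropyl group or a chain ending in a hydroxyl group on this nitrogen would read differently remains open.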